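The compounds below may be only part of what the source reports. "The series", "measured", "known", "first", "only" and "open" are said of these compounds alone.

Measured compounds:
- compound 1, `O=c1cc(-c2ccccc2)oc2cccc(OCCCN3CCC(O)CC3)c12`: 91 nM
- compound 2, `CN(C)CCCCCCCOc1ccc2oc(-c3ccccc3)cc(=O)c2c1`: 188 nM

Both were run in an assay on isolated protein (Cavia porcellus) with Sigma non-opioid intracellular receptor 1 (Homo sapiens) as the target, read by radioligand binding; a lower number here means a stronger inhibitor, a higher number a weaker inhibitor. Compound 1 gives 91 nM and compound 2 gives 188 nM; compound 2 therefore stands with the highest number of the two, its nearest neighbour being compound 1, whose number is lower by a margin that lies beyond the usual scatter. No pair of these compounds differs in a single place, so no isolated step has been worked out between them; what the pair shows is only that the compound carrying the 4-hydroxypiperidin-1-yl terminus sits at the lower number.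

Compound 3, `O=c1cc(-c2ccccc2)oc2ccc(OCCCCCCN3CCC(O)CC3)cc12`, has not yet been run in this assay. It differs from compound 2 as follows: 4-hydroxypiperidin-1-yl in place of (dimethylamino)methyl on a saturated chain carbon, six bonds along the chain from an oxygen on an aromatic ring.

Compound 1 also ends in a 4-hydroxypiperidin-1-yl group and gives 91 nM, so a move of compound 3 towards that figure is expected, a modest lowering of the number rather than a large one, and one that could still fall inside the scatter. The step from compound 2 is estimated at a 1.9-fold lower number from compound 2 to compound 3 (0.27 log units; within the scatter). For compound 3 the estimate in this assay is 100 nM, with a range from 40 nM to 250 nM.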

Compound 3, half-maximal inhibitory concentration: 121 nM
Compound 3: the middle estimate sits 1.2-fold (0.08 log units) below what was measured, within the range that was stated.
By their numbers in this assay, from the lowest: compounds 1, 3 and 2 (each within the scatter of the next, the first and the last beyond it).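

In this assay, this change now has a direct reading of a 1.6-fold lower number from compound 2 to compound 3 (0.19 log units; within the scatter), so at this place, six bonds along the chain from an oxygen on an aromatic ring, 4-hydroxypiperidin-1-yl and (dimethylamino)methyl cannot be told apart. The entering group adds a six-membered non-aromatic ring and a hydrogen-bond donor, yet the step stays within the scatter, which the earlier pair, differing in more than one place, could not show. Nothing available here bears on why the step is this small.

Compound 1 and compound 3 differ in more than one place, so the contributions of chain length and of the chain's point of attachment on the shared core remain unseparated. A plain piperidine or a morpholine at the chain end would test whether the hydroxyl of the 4-hydroxypiperidin-1-yl group counts for anything at this place, and a longer or shorter chain carrying the same terminal group on the core of compound 3 would isolate the effect of chain length.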